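Swapping Cyclohexyl for Benzyl on a Weak Inhibitor

This account rests on a few compounds, and the source may have more. Where it says the series, first, only, none or still open, it means among the compounds named here.

Compound 3 `CCC(C)C(NC(=O)n1nnc2ccccc21)C(=O)NC1CCCCC1` is the only one of the three measured compounds to give an actual number in a functional assay on HeLa cells (Homo sapiens) for inhibition; a lower number here means a stronger inhibitor, a higher number a weaker inhibitor; here compound 3 gives 63900 nM. Compound 1 `CCC(C)C(NC(=O)NO)C(=O)NC1CCCCC1` reaches only the limit of > 100000 nM in this assay. Compound 2 `CCC(C)C(NC(=O)NO)C(=O)NC(c1ccccc1)c1ccccc1` likewise reaches only the limit of > 100000 nM in this assay, so that two of the three values sit at the limit of > 100000 nM in this assay, at which 2 of the 3 values shown sit. Compound 4 `CCC(C)C(NC(=O)n1nnc2ccccc21)C(=O)NCc1ccccc1` has not yet been measured; it differs from compound 3 by benzyl in place of cyclohexyl on an amide-type nitrogen. Within the data shown here, no measured pair of compounds shows this exact change, so no step size is known from the data. The step of a 1.1-fold lower number from compound 3 to compound 4 (0.03 log units; within the scatter) is expected to stay within the usual scatter. Compound 4 is therefore estimated at 60000 nM, with a likely range from 20000 nM to 150000 nM in this assay.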

Compound 4, half-maximal inhibitory concentration: >= 100000 nM
Compound 4 gave a limit, no number (the forecaster's own chance of this, stated with the estimate: 35%); at least 1.6-fold (0.22 log units) between middle value and limit.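

Compound 4 gives no number in this assay, only a limit: the limit of >= 100000 nM in this assay, at which 1 of the 4 values shown sits. Benzyl in place of cyclohexyl on this amide-type nitrogen therefore brings no visible gain, and the change reads as an at least 1.5-fold higher number from compound 3 to compound 4 (0.19 log units; that floor lies within the scatter) in size. Since that floor stays within the scatter, a real loss at this position is not shown either. The compounds shown leave open how far compound 4 lies past its limit. They also leave open whether a longer alkyl chain or an amine on this nitrogen would give a clearly lower number than compound 3.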